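Lengthening the saturated chain on compound 3

The compounds below may be only part of what the source reports. "The series", "measured", "known", "first", "only" and "open" are said of these compounds alone.

compound 1 `CCCCCCCCCCCCCCCCOc1cc(OC)c(Br)cc1C(C)=O`: 6500000 nM
compound 2 `CCCCCCCCCCCCOc1cc(OC)ccc1C(C)=O`: 37400000 nM
compound 3 `CCCCCCCCCCCCCCOc1cc(OC)ccc1C(C)=O`: 43600000 nM

In a functional assay, with a stated time of 30 min (on this read-out lower numbers stand for stronger inhibition and higher numbers for weaker inhibition), compound 3 gives 43600000 nM, the highest number of the three but within the scatter of compound 2, while compound 1 lies clearly lower at 6500000 nM. Compound 4 `CCCCCCCCCCCCCCCCOc1cc(OC)ccc1C(C)=O` differs from compound 3 by ethyl in place of hydrogen on a saturated chain carbon, ten or more bonds along the chain from an oxygen on an aromatic ring. Among the compounds with values here, the only measured step of this kind, a 1.2-fold higher number from compound 2 to compound 3 (0.07 log units; within the scatter), stayed within the scatter, so no step beyond the scatter is expected in this assay. The estimated step is a 1.0-fold higher number from compound 3 to compound 4 (0.01 log units; within the scatter). The estimate for compound 4 is 45000000 nM, with an expected range of 20000000 nM to 95000000 nM.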

Compound 4, half-maximal inhibitory concentration: 39400000 nM
Compound 4: the middle estimate sits 1.1-fold (0.06 log units) above what was measured; measured number inside the range.
By their numbers in this assay, from the lowest: compound 1; then compounds 2, 4 and 3 (each within the scatter of the next).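

In this assay, the ethyl change repeated further along the chain gives a 1.1-fold lower number from compound 3 to compound 4 (0.04 log units; within the scatter), and the full butyl change gives a 1.1-fold higher number from compound 2 to compound 4 (0.02 log units; within the scatter), so chain lengthening stays within the scatter in both steps. Within the data shown here, with the chain held constant, hydrogen in place of bromo on an aromatic carbon gives a 6.1-fold higher number from compound 1 to compound 4 (0.78 log units; beyond the scatter), the only new step beyond the scatter. No evidence on the cause of either result is available.

From the compounds shown here alone, whether bromo gives a similar step on shorter chains remains open. So does the effect of a longer chain or of a carboxylic acid at the chain end.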